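The compounds below may be only part of what the source reports. "The series", "measured", "known", "first", "only" and "open" are said of these compounds alone.

In a functional assay on A549 cells (Homo sapiens) for inhibition, read by MTT assay, with a stated time of 24 h (on this read-out lower numbers stand for stronger inhibition of growth and higher numbers for weaker inhibition of growth), compound 3 `COc1ccccc1C(=O)n1c(-c2cn(C)c3ccc(Br)cc23)nc2ccccc21` stands at 12800 nM and sits level, within the usual scatter, with compound 1 `COc1ccccc1C(=O)n1c(-c2cn(C)c3ccccc23)nc2ccccc21` at 12300 nM in the same test series. Compound 2 `COc1ccc(C(=O)n2c(-c3cn(C)c4ccccc34)nc3ccccc32)cc1OC` has a lower number at 3100 nM and so shows stronger inhibition of growth than either of them.

Compound 4 `COc1ccc(C(=O)n2c(-c3cn(C)c4ccc(Br)cc34)nc3ccccc32)cc1OC` has not been measured yet. Going by the values given here, its only change from compound 3 is 3,4-dimethoxyphenyl in place of 2-methoxyphenyl on a carbonyl carbon.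

The same swap has been measured once, and it gave a 4.0-fold lower number from compound 1 to compound 2 (0.60 log units; beyond the scatter) as the closest guide available. The other measured step, bromo in place of hydrogen on an aromatic carbon, gave a 1.0-fold higher number from compound 1 to compound 3 (0.02 log units; within the scatter) and so offers no sign that the bromo alters the number. Among the compounds with values here, compound 4 keeps that bromo, but no measured pair shows the swap with the bromo present, so the transfer remains an assumption.

A modest step towards a lower number is therefore expected in this assay and is estimated as a 4.0-fold lower number from compound 3 to compound 4 (0.60 log units; beyond the scatter) on the strength of this single pair. For compound 4 the estimated value is 3200 nM (expected range 1300 nM to 7500 nM).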

Compound 4, concentration for 50% growth inhibition: 3400 nM
Estimate against measurement, compound 4: 1.1-fold (0.03 log units) below; measured number inside the range.
By their numbers in this assay, from the lowest: compounds 2 and 4 (each within the scatter of the next); then compounds 1 and 3 (each within the scatter of the next).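

In this assay, the swap to 3,4-dimethoxyphenyl on the carbonyl carbon has now been seen with the bromo present, giving a 3.8-fold lower number from compound 3 to compound 4 (0.58 log units; beyond the scatter), so it no longer rests on a single pair and holds on both cores: the same change on two cores in this assay, a 4.0-fold lower number (0.60 log units; beyond the scatter) from compound 1 to compound 2 and a 3.8-fold lower number (0.58 log units; beyond the scatter) from compound 3 to compound 4, 1.1-fold (0.02 log units) apart, within the scatter of two such steps

The bromo had earlier been seen only with 2-methoxyphenyl on the carbonyl carbon, and with 3,4-dimethoxyphenyl in that place it again leaves the number within the scatter, at a 1.1-fold higher number from compound 2 to compound 4 (0.04 log units; within the scatter), so its lack of effect also holds on both cores: the same change on two cores in this assay, a 1.0-fold higher number (0.02 log units; within the scatter) from compound 1 to compound 3 and a 1.1-fold higher number (0.04 log units; within the scatter) from compound 2 to compound 4, 1.1-fold (0.02 log units) apart, within the scatter of two such steps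

Across these four compounds, with none going against it, the group on the carbonyl carbon separates the lower numbers from the higher ones, while the bromo makes no measurable difference.

The swap alters the methoxy count and the arrangement of the groups on the phenyl ring in one step, so the compounds shown cannot say which part of it carries the lower number. They also leave open how the number would respond to an amine or a carboxylic acid on that phenyl ring, or to a group other than bromo on the aromatic carbon, such as a nitrile.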